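Triazole aryl swap on the shared core

This account rests on a few compounds, and the source may have more. Where it says the series, first, only, none or still open, it means among the compounds named here.

Compound 1 `O=C1O[C@H]([C@@H](O)Cn2cc(-c3ccc(Br)cc3)nn2)C(OCc2ccccc2)=C1OCc1ccccc1` is the reference point of these notes. Within the data shown here, in a functional assay on MCF7 cells (Homo sapiens) for antiproliferative activity, read by MTT assay, with a stated time of 72 h (a higher number here means a weaker inhibitor, a lower number a stronger inhibitor), compound 1 gives 5620 nM, the only numerical reading in hand. Compound 2 `CC(C)(C)OC(=O)N1CCN(C(=S)SCc2cn(C[C@H](O)[C@H]3OC(=O)C(OCc4ccccc4)=C3OCc3ccccc3)nn2)CC1` returns only a limit in this assay, namely > 100000 nM, which places it at the limit of > 100000 nM in this assay, at which 1 of the 2 values shown sits, and leaves no number to compare. Compound 1 thus stands alone as the single quantified point. Compound 3 `O=C1O[C@H]([C@@H](O)Cn2cc(-c3cc(F)cc(F)c3)nn2)C(OCc2ccccc2)=C1OCc1ccccc1` is not yet measured; it differs from compound 1 as follows: 3,5-difluorophenyl in place of 4-bromophenyl on an aromatic carbon. Among the measured compounds shown here, no pair of measured compounds with a single change exists here, so no measured step guides this swap. The expectation for compound 3 in this assay is a 1.4-fold higher number from compound 1 to compound 3 (0.15 log units; within the scatter), a shift not expected to exceed the usual scatter. Compound 3 is estimated at 8000 nM, with a range from 3000 nM to 25000 nM.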

Compound 3, half-maximal inhibitory concentration: 27700 nM
Compound 3: middle estimate off by 3.5-fold (0.54 log units), on the low side; the measured number lies above the stated range.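

In this assay, with 3,5-difluorophenyl in place of 4-bromophenyl on the aromatic carbon of the five-membered aromatic ring with 3 nitrogen, the series shows a 4.9-fold higher number from compound 1 to compound 3 (0.69 log units; beyond the scatter) as its first readable single change. The reading therefore responds to the aryl group at this position, and the two groups are not interchangeable here, with 4-bromophenyl giving the lower number. Nothing in hand accounts for the shift.

On these data alone, the swap changes the halogen, the number of halogens and their places on the phenyl ring all at once, so the part of the change that drives the step remains open. A plain phenyl or an aminophenyl group on the same carbon would help to show how far the reading depends on halogen substitution at all.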